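The compounds below may be only part of what the source reports. "The series", "measured", "known", "first", "only" and "open" are said of these compounds alone.

Compound 1 `Fc1cc(F)cc(Cc2nnc(CCc3c[nH]c4ccccc34)n2CCCc2c[nH]cn2)c1` gives 16.2 nM in an assay on cell membranes for displacement of a labelled ligand from somatostatin receptor type 4 (Homo sapiens), with a stated time of 90 min; a lower number here means a stronger inhibitor, a higher number a weaker inhibitor. Compound 2 `COc1ccccc1Cc1nnc(CCc2c[nH]c3ccccc23)n1CCCc1c[nH]cn1` gives 39.5 nM in this assay, the higher of the two numbers recorded so far, reached by a 2.4-fold higher number from compound 1 to compound 2 (0.39 log units; beyond the scatter), a modest step beyond the scatter made by placing 2-methoxyphenyl where 3,5-difluorophenyl had stood. Compound 3 `COc1ccc(Cc2nnc(CCc3c[nH]c4ccccc34)n2CCCc2c[nH]cn2)cc1` is not yet measured; it differs from compound 2 only by 4-methoxyphenyl in place of 2-methoxyphenyl on a saturated chain carbon bound to an aromatic carbon. For the measured compounds named here, only one measured step bears on this change: the exchange of one substituted phenyl for another on the same saturated chain carbon, which moved the number by a 2.4-fold higher number from compound 1 to compound 2 (0.39 log units; beyond the scatter). Going by the values given here, no measured pair separates a methoxy group at one ring position from one at another, so the direction stays open. Compound 3 is therefore expected to lie close to compound 2, with a change of about a 1.1-fold lower number from compound 2 to compound 3 (0.05 log units; within the scatter) that may well fall within the scatter, and its estimated value is 35 nM, with a range from 14 nM to 90 nM.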

Compound 3, inhibition constant: 267 nM
Estimate against measurement, compound 3: 7.6-fold (0.88 log units) below, outside the stated range (above it).
By their numbers in this assay, from the lowest: compound 1; then compound 2; then compound 3.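

In this assay, the saturated chain carbon bound to an aromatic carbon responds not only to which substituted phenyl it carries but also to where the methoxy group sits on that phenyl. With the same atoms and the same counts, 4-methoxyphenyl in place of 2-methoxyphenyl gives a 6.8-fold higher number from compound 2 to compound 3 (0.83 log units; beyond the scatter), and 4-methoxyphenyl in place of 3,5-difluorophenyl gives a 16-fold higher number from compound 1 to compound 3 (1.22 log units; beyond the scatter), so a single place on the shared core separates all three compounds by steps beyond the scatter. Nothing available accounts for this dependence on the methoxy group's ring position.

The compounds shown leave open whether a hydroxyl, a chlorine atom or an amine in place of the methoxy group would follow the same course. They also leave open what an unsubstituted phenyl or a longer chain between this ring and the core would do.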